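A few compounds are considered here, and "the series" means these few. Any claim that something is new, unique, unknown or untested is made for them only; others in the source may bear on it.

Three compounds that share one core and differ in the chain of their ester have been measured in a functional assay on HeLa cells (Homo sapiens) for cytotoxicity, read by cell counting, with a stated time of 48 h; on this read-out lower numbers stand for an effect already at smaller amounts and higher numbers for an effect only at larger amounts of compound. Compound 1 `CCCCCCCCCCCCCCCC(=O)O[C@H]1[C@H](O)[C@H](n2ccc(N)nc2=O)O[C@@H]1CO` gives 0.24 ug/mL, compound 2 `CCCCCC(=O)O[C@H]1[C@H](O)[C@H](n2ccc(N)nc2=O)O[C@@H]1CO` gives 0.05 ug/mL, and compound 3 `CCCCCCCC/C=C\CCCCCCCCCCCC(=O)O[C@H]1[C@H](O)[C@H](n2ccc(N)nc2=O)O[C@@H]1CO` gives 0.16 ug/mL. Compound 3 therefore stands within the scatter of compound 1 and clearly apart from compound 2.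

Compound 4 `CCCCCCCCCCCC(=O)O[C@H]1[C@H](O)[C@H](n2ccc(N)nc2=O)O[C@@H]1CO` has not yet been measured. It keeps the core but carries a shorter chain than compound 3: hydrogen in place of dec-1-en-1-yl on a saturated chain carbon, ten or more bonds along the chain from a carbonyl carbon, which means hydrogen in place of dec-1-en-1-yl on a saturated chain carbon, ten or more bonds along the chain from a carbonyl carbon.

For the measured compounds named here, two measured steps bear on this change. The closer in kind is a 4.8-fold lower number from compound 1 to compound 2 (0.68 log units; beyond the scatter), which also cuts a long piece from the chain, with hydrogen in place of decyl. The other, a 1.5-fold lower number from compound 1 to compound 3 (0.18 log units; within the scatter), shows that a change far out along the chain need not move the number clearly. Compound 4 also keeps more chain than compound 2, so only part of the larger step seems likely to carry over.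

A small move toward a lower number is expected, estimated as a 1.6-fold lower number from compound 3 to compound 4 (0.20 log units; within the scatter), and this would not clearly exceed the scatter. The estimated value for compound 4 is 0.1 ug/mL, with an expected range from 0.04 ug/mL to 0.25 ug/mL.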

Compound 4, concentration for half-maximal effect: 0.08 ug/mL
The estimate for compound 4 lay 1.3-fold (0.10 log units) above the measured number; measured number inside the range.
By their numbers in this assay, from the lowest: compounds 2, 4, 3 and 1 (each within the scatter of the next, the first and the last beyond it).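

In this assay, putting hydrogen in place of dec-1-en-1-yl on a saturated chain carbon, ten or more bonds along the chain from a carbonyl carbon, gives a 2.0-fold lower number from compound 3 to compound 4 (0.30 log units; within the scatter), and the comparison with the shorter chain gives a 1.6-fold higher number from compound 2 to compound 4 (0.20 log units; within the scatter), so compound 4 cannot be told apart from either of these two. For the compounds shown here, the new information comes from the saturated chain: hydrogen in place of butyl at this same place gives a 3.0-fold lower number from compound 1 to compound 4 (0.48 log units; beyond the scatter), which shows that a cut much smaller than the one leading to compound 2 already sets a compound clearly apart from compound 1. No measurement at hand explains these steps.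

Going by these compounds, it remains open how a saturated chain as long as that of compound 3 would compare, so the double bond cannot be judged apart from chain length. Also open, on these data alone, is what this assay would show with an amine or a carboxylic acid at this same place on the chain, or with a chain shorter than that of compound 2.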